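Trading 5-methylfuran-2-yl for 2-methylphenyl

The compounds below may be only part of what the source reports. "The series", "measured", "known", "first", "only" and "open" are said of these compounds alone.

In a functional assay on HCT-15 cells (Homo sapiens) for cytotoxicity, read by ELISA, with a stated time of 4 days (on this read-out lower numbers stand for stronger inhibition and higher numbers for weaker inhibition), compound 1 (`Clc1ccc(-c2cc(-c3ccoc3)cc(-c3ccco3)n2)s1`) gives 1280 nM and compound 2 (`Cc1ccc(-c2cc(-c3ccoc3)cc(-c3ccc(Cl)s3)n2)o1`) gives 790 nM. For the measured compounds named here, the one measured step, a 1.6-fold lower number from compound 1 to compound 2 (0.21 log units; within the scatter), lies within the scatter, so compound 2 stands level with its only neighbour. Compound 3 (`Cc1ccccc1-c1cc(-c2ccoc2)cc(-c2ccc(Cl)s2)n1`) carries 2-methylphenyl in place of 5-methylfuran-2-yl on an aromatic carbon. Going by the values given here, that measured step only put methyl in place of hydrogen, and no measured pair exchanges a whole ring, so it is a weak guide. No change beyond the scatter is expected, and the expected step is a 1.3-fold higher number from compound 2 to compound 3 (0.10 log units; within the scatter). For compound 3 the estimate is 1000 nM, with an expected range of 350 nM to 3000 nM.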

Compound 3, half-maximal inhibitory concentration: 990 nM
For compound 3 the middle estimate is 1.0-fold (0.00 log units) above the measured one; the measured number falls inside the stated range.
By their numbers in this assay, from the lowest: compounds 2, 3 and 1 (each within the scatter of the next).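

On an aromatic carbon next to the ring nitrogen, whole rings can now be compared in this assay: 2-methylphenyl in place of 5-methylfuran-2-yl gives a 1.3-fold higher number from compound 2 to compound 3 (0.10 log units; within the scatter) and 2-methylphenyl in place of furan-2-yl gives a 1.3-fold lower number from compound 1 to compound 3 (0.11 log units; within the scatter) as the second step. A six-membered aromatic ring of carbon only therefore stands level with both furan rings here, even without their oxygen. No measurement is available that would explain this level result.

The compounds shown leave open whether an amine, a carboxylic acid or a longer chain on this carbon would move the number beyond the scatter.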